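From thiophen-2-yl to furan-2-yl: a cytotoxicity estimate

A few compounds are considered here, and "the series" means these few. Any claim that something is new, unique, unknown or untested is made for them only; others in the source may bear on it.

Compound 1 `O=[N+]([O-])c1c(CS(=O)(=O)c2ccccc2)nc2c(-c3cccc(C(F)(F)F)c3)cc(Cl)cn12`: > 12500 nM, a limit
Compound 2 `O=[N+]([O-])c1c(CS(=O)(=O)c2ccccc2)nc2c(-c3cccs3)cc(Cl)cn12`: > 3900 nM, a limit

In an ADME assay on HepG2 cells (Homo sapiens) for cytotoxicity, read by MTT assay, with a stated time of 72 h (on this read-out lower numbers stand for higher toxicity in this test and higher numbers for lower toxicity in this test), compound 2 gives > 3900 nM, which is a limit and not a number. Compound 2 therefore has no exact place on the scale, and neither does compound 1.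

Compound 3 `O=[N+]([O-])c1c(CS(=O)(=O)c2ccccc2)nc2c(-c3ccco3)cc(Cl)cn12` has not yet been measured. It carries furan-2-yl in place of thiophen-2-yl on an aromatic carbon. The ring sulfur gives way to oxygen, and the rest of the molecule stays the same.

Going by the values given here, only one measured step bears on this change, the exchange of the group at this same place: a step that the two limits leave unreadable from compound 1 to compound 2. That step has no readable size to carry over and shows no direction. The expectation in this assay is therefore no step beyond the scatter, and a report of only a limit is likely again.

For compound 3 the estimated value is 5000 nM, with an expected range from 2500 nM to 15000 nM. This estimate means an expected step that the limit leaves unreadable from compound 2 to compound 3.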

Compound 3, half-maximal cytotoxic concentration: > 3900 nM
Compound 3: no number, only a limit; the forecaster's own chance of this, stated with the estimate: 75%; the middle value is on the limit's open side.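

In this assay, going by these compounds alone, compound 1, compound 2 and compound 3 all give only limits and not numbers, and no step among the three can be read. The compounds shown leave open where each one sits on the scale, and whether thiophen-2-yl, furan-2-yl or 3-(trifluoromethyl)phenyl makes any difference to cytotoxicity.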